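The source may hold more compounds than are shown below. What is called first, only, known or untested is meant among the compounds shown, and "the series" means these compounds.

Compound 2 `CC(=O)c1ccc(NC(=O)CSC(=S)N[C@H]2CCOC2=O)cc1` is the starting point. In a functional assay on MCF7 cells (Homo sapiens) for cytotoxicity, read by MTT assay, with a stated time of 72 h (a higher number here means a weaker inhibitor, a lower number a stronger inhibitor), compound 2 gives only a limit of the assay, > 128000 nM. Compound 1 `O=C(CSC(=S)N[C@H]1CCOC1=O)Nc1ccc(Cl)cc1` gives 50300 nM in this assay, and compound 3 `CCCCc1ccc(NC(=O)CSC(=S)N[C@H]2CCOC2=O)cc1` gives 40200 nM. The steps of an at least 2.5-fold higher number from compound 1 to compound 2 (0.40 log units; beyond the scatter) and an at least 3.1-fold lower number from compound 2 to compound 3 (0.50 log units; beyond the scatter) both end or begin at the limit (the limit of > 128000 nM in this assay, at which 1 of the 3 values shown sits), while a 1.3-fold lower number from compound 1 to compound 3 (0.10 log units; within the scatter) stays within the scatter. Compound 4 `O=C(CSC(=S)N[C@H]1CCOC1=O)Nc1ccc(C(=O)/C=C/c2ccc(Cl)cc2)cc1` differs from compound 2 by 2-(4-chlorophenyl)ethenyl in place of methyl on a carbonyl carbon. Within the data shown here, none of the measured steps touches this carbonyl carbon; they only swapped the group on the aromatic ring, so the bearing is indirect. Because compound 2 stands at the limit (the limit of > 128000 nM in this assay, at which 1 of the 3 values shown sits), a lowering step is expected for compound 4, an at least 3.2-fold lower number from compound 2 to compound 4 (0.50 log units; beyond the scatter). Compound 4 is estimated at 40000 nM, with a range from 10000 nM to 128000 nM.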

Compound 4, half-maximal inhibitory concentration: 20300 nM
Beside the measured number, compound 4's estimate is 2.0-fold (0.29 log units) above it; measured number inside the range.
By their numbers in this assay, from the lowest: compounds 4, 3 and 1 (each within the scatter of the next, the first and the last beyond it). At a limit, above all of these: compound 2.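

Swapping methyl for 2-(4-chlorophenyl)ethenyl on the carbonyl carbon gives an at least 6.3-fold lower number from compound 2 to compound 4 (0.79 log units; beyond the scatter) in this assay. Among these compounds, earlier steps changed only the group on the aromatic ring, so this is the first sign that the carbonyl can stay while the group on it grows. The true size of this step remains unknown, since compound 2 gives only a limit: the limit of > 128000 nM in this assay, at which 1 of the 4 values shown sits.

The compounds shown do not separate the contributions of the double bond, the ring and the chlorine within the new group. Going by these compounds, how an amine or a plain phenyl on that carbonyl carbon would compare also remains open.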